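Series notes: alkoxy variation on the shared core

The compounds below may be only part of what the source reports. "The series", "measured", "known", "first", "only" and "open" are said of these compounds alone.

Measured so far in a functional assay on aorta (strain Wistar) for inhibition, with Thoracic aorta (Rattus norvegicus) as the target; a lower number here means a stronger inhibitor, a higher number a weaker inhibitor:
compound 1 `CCOc1nc(-c2cc3ccccc3o2)cc(-c2cccc3ccccc23)c1C#N` gives 344000 nM
compound 2 `COc1nc(-c2cc3ccccc3o2)cc(-c2ccc(Cl)cc2Cl)c1C#N` gives 322000 nM

Going by the values given here, only two compounds carry a number in this assay. Compound 2 and compound 1 differ in two places at once, so no single step can be read between them; their two values lie within the usual scatter of each other, and neither compound can be placed above or below the other on this evidence. Both sit at the weak end of what this assay reports.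

Compound 3 `CCOc1nc(-c2cc3ccccc3o2)cc(-c2ccc(Cl)cc2Cl)c1C#N` has not yet been measured. It differs from compound 2 by methyl in place of hydrogen on a saturated chain carbon bound to an oxygen on an aromatic ring, the methoxy of compound 2 becoming ethoxy. Among the compounds with values here, no measured pair isolates this change, so its size is unknown here. Compound 1, which already carries the ethoxy group, reads close to compound 2, which gives some ground to expect little movement. For compound 3 the expected step is a 1.0-fold lower number from compound 2 to compound 3 (0.00 log units; within the scatter), which is taken as none beyond the scatter. The estimate for compound 3 is therefore 320000 nM, with a range from 150000 nM to 700000 nM.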

Compound 3, half-maximal inhibitory concentration: 442000 nM
The estimate for compound 3 lay 1.4-fold (0.14 log units) below the measured number; low and high end bracket the measured number.
By their numbers in this assay, from the lowest: compounds 2, 1 and 3 (each within the scatter of the next).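

In this assay the change from methoxy to ethoxy now has a reading of its own, a 1.4-fold higher number from compound 2 to compound 3 (0.14 log units; within the scatter), so methyl in place of hydrogen on this saturated chain carbon bound to an oxygen on an aromatic ring gives a step that cannot be told apart from repeat measurement. Compound 3 also opens a second single-place comparison, with 2,4-dichlorophenyl in place of naphthalen-1-yl on an aromatic carbon, and that reading, a 1.3-fold higher number from compound 1 to compound 3 (0.11 log units; within the scatter), likewise stays within the scatter, so neither position has yet shown a step beyond it. Nothing measured here bears on why either step has the size it has.

Going by these compounds, whether a longer chain such as propoxy, or an amine in place of the alkoxy group, would carry the number beyond the scatter remains open. Also open, on these data alone, are whether the methoxy to ethoxy step keeps its size with naphthalen-1-yl on the shared core, and whether a carboxylic acid in place of the nitrile would change the reading in this assay.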